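This account rests on a few compounds, and the source may have more. Where it says the series, first, only, none or still open, it means among the compounds named here.

Measured so far:
compound 1 `CC(=O)O[C@H]1CC[C@]2(C)[C@H](CC[C@@](C)(O)[C@H]2CC[C@@H]2C(C)=CC[C@H]3[C@H](CC[C@]3(C)O)C2(C)C)OC1(C)C` — 38000 nM
compound 2 `CC(=O)O[C@H]1CC[C@]2(C)[C@H](CC[C@@](C)(O)[C@H]2CC[C@@H]2C(C)=CC[C@H]3[C@H](CC[C@]3(C)OC(C)=O)C2(C)C)OC1(C)C` — 26200 nM
compound 3 `CC1=CC[C@H]2[C@H](CC[C@]2(C)O)C(C)(C)[C@@H]1CC[C@H]1[C@]2(C)CC/C(=N/O)C(C)(C)O[C@H]2CC[C@@]1(C)O` — 42700 nM

In a functional assay on MDA-MB-231 cells (Homo sapiens) for antiproliferative activity, read by MTT assay, with a stated time of 72 h (a higher number here means a weaker inhibitor, a lower number a stronger inhibitor), compound 1 gives 38000 nM, the second highest of the three numbers. Compound 3 gives 42700 nM and compound 2 gives 26200 nM; both sit within the scatter of compound 1, so no order among the three can be read from these values.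

Compound 4 `CC1=CC[C@H]2[C@H](CC[C@]2(C)O)C(C)(C)[C@@H]1CC[C@H]1[C@]2(C)CC[C@H](OC(=O)c3ccccc3Cl)C(C)(C)O[C@H]2CC[C@@]1(C)O` differs from compound 1 in one place: 2-chlorophenyl in place of methyl on a carbonyl carbon. Among the measured compounds shown here, the only measured step in the set, a 1.5-fold lower number from compound 1 to compound 2 (0.16 log units; within the scatter), changes an ester for a free hydroxyl on a different oxygen of the core and stayed within the scatter; it does not test a change at the carbonyl carbon of the acetoxy group, and nothing else measured does. With no step bearing directly on the change, and the two listed steps both flat, no movement beyond the scatter is expected, so the estimated step is a 1.2-fold lower number from compound 1 to compound 4 (0.07 log units; within the scatter). Compound 4 is therefore expected to give about 32000 nM in this assay, in the range 10000 nM to 95000 nM.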

Compound 4, half-maximal inhibitory concentration: 24300 nM
Compound 4: middle estimate off by 1.3-fold (0.12 log units), on the high side; the range from low to high includes it.
By their numbers in this assay, from the lowest: compounds 4, 2, 1 and 3 (each within the scatter of the next).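

In this assay, 2-chlorophenyl in place of methyl on the carbonyl carbon leaves the read-out within the scatter (a 1.6-fold lower number from compound 1 to compound 4 (0.19 log units; within the scatter)). Among the compounds shown here, this is the first reading at this carbonyl carbon: the earlier step (a 1.5-fold lower number from compound 1 to compound 2 (0.16 log units; within the scatter)) concerned acetyl on a different oxygen, so the carbonyl carbon had not been tested. The position therefore carries an entering group of seven heavy atoms with a six-membered aromatic ring and no change beyond the scatter, and no measured evidence bears on this result.

Still open, from the compounds shown here alone, is how a plain phenyl, a longer alkyl chain, or a group carrying an amine or a carboxylic acid would read at this carbonyl carbon. Also open is whether any change on the shared core moves the number beyond the scatter, as every step shown so far stays within it.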